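The source may report more compounds than this note shows. Statements on the series, on what has been measured and on what is new or still open speak of the compounds shown alone.

Measured so far:
compound 1 `O=C1N[C@H]2[C@H](CS[C@H]2CCCCCc2cn(Cc3ccccc3O)nn2)N1` — in an assay on isolated protein for inhibition of biotin--protein ligase (Homo sapiens), read by scintillation counting, with a stated time of 10 min (on this read-out lower numbers stand for stronger inhibition and higher numbers for weaker inhibition), compound 1 gives only a limit, > 16000 nM.
compound 2 `Nc1ccccc1Cn1cc(CCCCC[C@@H]2SC[C@@H]3NC(=O)N[C@@H]32)nn1` — in this assay compound 2 gives only a limit, > 16000 nM.
compound 3 `Cc1cccc(Cn2cc(CCCCC[C@@H]3SC[C@@H]4NC(=O)N[C@@H]43)nn2)c1` — in this assay compound 3 gives only a limit, > 16000 nM.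

Compound 3 therefore stands at the limit of this assay, as do the other two; this is the limit of > 16000 nM in this assay, at which 3 of the 3 values shown sit. The steps among the measured compounds are all unreadable: a step that the two limits leave unreadable from compound 1 to compound 2, a step that the two limits leave unreadable from compound 1 to compound 3 and a step that the two limits leave unreadable from compound 2 to compound 3. Among the compounds with values here, no measured step has a size, so none gives a direction for the next change.

Compound 4 `O=C1N[C@H]2[C@H](CS[C@H]2CCCCCc2cn(Cc3ccc(Cl)cc3)nn2)N1` is the next one to be measured in this assay. Its change from compound 3 is 4-chlorophenyl in place of 3-methylphenyl on a saturated chain carbon bound to an aromatic nitrogen. The aryl group on the saturated chain carbon bound to the aromatic nitrogen has been varied in each of the measured compounds without leaving the limit, with 2-hydroxyphenyl, 2-aminophenyl and 3-methylphenyl, and 4-chlorophenyl is a change of the same kind. The expectation is therefore that compound 4 also sits at the limit, with no readable step.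

Compound 4 is expected at about 20000 nM, in the range 8000 nM to 60000 nM. The step this implies, a step that the limit leaves unreadable from compound 3 to compound 4, is an estimate of no readable change.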

Compound 4, inhibition constant: > 16000 nM
Compound 4: a limit, no number (the forecaster's own chance of this, stated with the estimate: 80%); the middle value lies beyond the limit too.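

In this assay compound 4 gives only a limit, as do compound 1, compound 2 and compound 3, so no step among these compounds can be read: the limit of > 16000 nM in this assay, at which 4 of the 4 values shown sit. The compounds shown leave open whether any aryl group at this place gives a measurable inhibition constant.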